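From Ethynyl to Nitro: A Single Group Exchanged

The source may hold more compounds than are shown below. What is called first, only, known or untested is meant among the compounds shown, and "the series" means these compounds.

Measured in a functional assay on HCT-116 cells (Homo sapiens) for antiproliferative activity, read by MTT assay, with a stated time of 72 h; on this read-out lower numbers stand for stronger inhibition and higher numbers for weaker inhibition:
- Compound 1 `O=C(CCc1cccc2c1B(O)OC2)Nc1nccs1`: > 100000 nM (a limit, not a number)
- Compound 2 `O=C(CCc1cccc2c1B(O)OC2)Nc1ccc(F)cc1`: 650 nM
- Compound 3 `C#Cc1ccc(NC(=O)CCc2cccc3c2B(O)OC3)cc1`: 45000 nM

Compound 3 holds the higher of the two true numbers, which means the weaker inhibition. Compound 4 `O=C(CCc1cccc2c1B(O)OC2)Nc1ccc([N+](=O)[O-])cc1` differs from it as follows: nitro in place of ethynyl on an aromatic carbon. The ethynyl group of compound 3 thus gives way to a nitro group, and the rest of the molecule stays the same. The closest guide is a 69-fold higher number from compound 2 to compound 3 (1.84 log units; beyond the scatter), a large step made at this same place. The other large step, an at least 150-fold lower number from compound 1 to compound 2 (2.18 log units; beyond the scatter), exchanged the whole group on the amide-type nitrogen. Compound 3 already lies far above compound 2, so a sizeable move to a lower number is expected in this assay. The expected change is a 7.5-fold lower number from compound 3 to compound 4 (0.88 log units; beyond the scatter). The estimated value for compound 4 is 6000 nM, with an expected range from 600 nM to 50000 nM.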

Compound 4, half-maximal inhibitory concentration: > 100000 nM
Compound 4: a limit, no number; the forecaster's own chance of this, stated with the estimate: 10%; middle value at least 16-fold (1.22 log units) away from the limit.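

Nitro does not win back what ethynyl lost at this position: in this assay the exchange gives an at least 2.2-fold higher number from compound 3 to compound 4 (0.34 log units; beyond the scatter). Set against fluoro, the change is larger still, with an at least 150-fold higher number from compound 2 to compound 4 (2.18 log units; beyond the scatter), so among the three groups shown on this aromatic carbon, only fluoro gives a low number. Compound 4 carries a limit, not a number: the limit of > 100000 nM in this assay, at which 2 of the 4 values shown sit.

On these data alone, how far the activity falls beyond that limit stays open. So does whether a chloro group or an amine at this place would stay close to fluoro or fall away like ethynyl and nitro.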